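The source may hold more compounds than are shown below. What is called first, only, known or untested is meant among the compounds shown, and "the series" means these compounds.

Three compounds measured so far in a functional assay on PC-3 cells (Homo sapiens) for cytotoxicity, read by MTT assay, with a stated time of 72 h; a lower number here means a stronger inhibitor, a higher number a weaker inhibitor
- compound 1 `[O-][n+]1nc(NCOCc2ccc(C(F)(F)F)cc2)[n+]([O-])c2ccccc21` gives 9310 nM
- compound 2 `[O-][n+]1nc(NCOCc2ccc(Cl)cc2)[n+]([O-])c2ccccc21` gives 5100 nM
- compound 3 `COc1ccc(COCNc2n[n+]([O-])c3ccccc3[n+]2[O-])cc1` gives 52800 nM

These three differ only in the group on the aromatic ring. Compound 1 and compound 2 stand together at the low end of the numbers, within the scatter of each other, and compound 3 has the highest number.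

The next compound is compound 4 `[O-][n+]1nc(NCOCc2ccccc2)[n+]([O-])c2ccccc21`, which has hydrogen in place of trifluoromethyl on an aromatic carbon of compound 1 (hydrogen in place of trifluoromethyl on an aromatic carbon). The measured steps all concern this same place on the ring. Chloro for trifluoromethyl is a step within the scatter a 1.8-fold lower number from compound 1 to compound 2 (0.26 log units; within the scatter). Methoxy for trifluoromethyl is a modest step of a 5.7-fold higher number from compound 1 to compound 3 (0.75 log units; beyond the scatter), and methoxy for chloro is a large one a 10-fold higher number from compound 2 to compound 3 (1.02 log units; beyond the scatter).

Going by the values given here, no compound with hydrogen at this place has been measured, so these steps only mark out a likely span. Its number could lie anywhere from the level of compound 2 to that of compound 3, and a middle position seems the fairest guess. A small step toward a higher number, near the edge of the scatter, is therefore expected a 2.1-fold higher number from compound 1 to compound 4 (0.33 log units; beyond the scatter). For compound 4 the estimated value is 20000 nM, with an expected range from 7000 nM to 55000 nM.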

Compound 4, half-maximal inhibitory concentration: 11900 nM
The estimate for compound 4 lay 1.7-fold (0.23 log units) above the measured number, and the stated range covers the measured number.
By their numbers in this assay, from the lowest: compounds 2, 1 and 4 (each within the scatter of the next, the first and the last beyond it); then compound 3.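

Taking away the trifluoromethyl group entirely gives a 1.3-fold higher number from compound 1 to compound 4 (0.11 log units; within the scatter) in this assay, so at this place on the aromatic ring, trifluoromethyl and plain hydrogen cannot be told apart in this measurement. Going by these compounds alone, compound 4 also supplies the reference that the earlier compounds lacked, a ring with no added group, and against it methoxy stands clearly apart, with a 4.4-fold lower number from compound 3 to compound 4 (0.65 log units; beyond the scatter) showing that hydrogen in place of methoxy brings the number down. Chloro also stands apart from hydrogen, with a 2.3-fold higher number from compound 2 to compound 4 (0.37 log units; beyond the scatter) beyond the scatter, although compound 1 lies within the scatter of both compound 2 and compound 4, so the three form a loose group with no sharp break among them, and only compound 3 sits well away from it.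

Nothing measured here explains why these groups give the numbers they do. The compounds shown leave open how an amine, a carboxylic acid or a simple methyl group would read at this same place, and whether a second group elsewhere on this ring would change the picture.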